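Shifting the hydroxyl of a hydroxyphenyl group in three analogues

A few compounds are considered here, and "the series" means these few. Any claim that something is new, unique, unknown or untested is made for them only; others in the source may bear on it.

Compound 1 `Oc1ccc(-c2cc(-c3cccs3)cc(-c3ccccc3O)n2)cc1`: in a functional assay on DU-145 cells (Homo sapiens) for cytotoxicity, read by CCK-8 assay (on this read-out higher numbers stand for weaker inhibition and lower numbers for stronger inhibition), compound 1 reaches only the assay limit of > 50000 nM.
Compound 2 `Oc1ccc(-c2cc(-c3cccs3)cc(-c3cccc(O)c3)n2)cc1`: in this assay compound 2 gives 1890 nM.
Compound 3 `Oc1cccc(-c2cc(-c3ccsc3)cc(-c3ccccc3O)n2)c1`: in this assay compound 3 reaches only the assay limit of > 50000 nM.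

Compound 2 differs from compound 1 in one place, (3-hydroxyphenyl in place of 2-hydroxyphenyl on an aromatic carbon), and this change made an at least 26-fold lower number from compound 1 to compound 2 (1.42 log units; beyond the scatter). Compound 4 `Oc1cccc(-c2cc(-c3ccsc3)cc(-c3cccc(O)c3)n2)c1` is not yet measured; it differs from compound 3 by 3-hydroxyphenyl in place of 2-hydroxyphenyl on an aromatic carbon, the same kind of change, but around a different place: in compound 1 the position is meta to a 4-hydroxyphenyl group and meta to a thiophen-2-yl group, whereas in compound 3 it is meta to a 3-hydroxyphenyl group and meta to a thiophen-3-yl group. The difference between the two cores is not broken down here. Two of the three values sit at the limit of > 50000 nM in this assay, at which 2 of the 3 values shown sit, so the starting point of compound 3 is a limit rather than a number. Compound 4 is expected to show a step of an at least 12-fold lower number from compound 3 to compound 4 (1.09 log units; beyond the scatter), resting on the earlier step from compound 1 to compound 2 in this assay. Compound 4 is therefore estimated at 4000 nM, within 1000 nM to 30000 nM.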

Compound 4, half-maximal inhibitory concentration: 1310 nM
Estimate against measurement, compound 4: 3.1-fold (0.48 log units) above, and the stated range covers the measured number.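

In this assay, putting 3-hydroxyphenyl in place of 2-hydroxyphenyl on the core of compound 3 gave an at least 38-fold lower number from compound 3 to compound 4 (1.58 log units; beyond the scatter), so the change went the same way on this second core as on the first. Set side by side, the two steps are both large, which shows that the change carried over between these two cores, though two cores are all that can be compared here: the same change on two cores in this assay, an at least 26-fold lower number (1.42 log units; beyond the scatter) from compound 1 to compound 2 and an at least 38-fold lower number (1.58 log units; beyond the scatter) from compound 3 to compound 4; the limit leaves it open whether they differ What this does not show is how large either step really is, or whether one exceeds the other, because compound 1 and compound 3 each stand at a limit of the assay rather than at a number: the limit of > 50000 nM in this assay, at which 2 of the 4 values shown sit.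

The compounds shown leave open whether a methoxy group or an amine in place of the hydroxyl would give a similar step. They also leave open whether the step would hold on a core carrying a plain phenyl or a furan in place of the thiophene.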